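A few compounds are considered here, and "the series" means these few. Any claim that something is new, unique, unknown or untested is made for them only; others in the source may bear on it.

Compound 1 `CSCc1ccc(Nc2ncc(Cc3c(F)cccc3F)o2)cc1`: > 100000 nM
Compound 2 `Fc1cccc(F)c1Cc1cnc(Nc2ccc(Oc3ccncc3)c(Cl)c2)o1`: 21000 nM
Compound 3 `COCc1ccc(Nc2nnc(Cc3c(Cl)cccc3Cl)o2)cc1`: 100000 nM

In an ADME assay on MT2 cells (Homo sapiens) for cytotoxicity, read by MTT assay (on this read-out lower numbers stand for higher toxicity in this test and higher numbers for lower toxicity in this test), compound 1 gives only a limit, > 100000 nM, and no number, so its place among the measured compounds is known only as a bound (the limit of > 100000 nM in this assay, at which 1 of the 3 values shown sits). Compound 2 gives 21000 nM in this assay. Compound 3 gives 100000 nM in this assay. Among the compounds with values here, no pair of these three compounds differs in one place, so no measured step is available. Compound 4 `Fc1cccc(F)c1Cc1cnc(Nc2ccc(COCc3ccco3)cc2)o1` differs from compound 1 in this way: (furan-2-yl)methoxy in place of methylsulfanyl on a saturated chain carbon bound to an aromatic carbon. With nothing measured for this change, the expected step of an at least 1.6-fold lower number from compound 1 to compound 4 (0.22 log units; that floor lies within the scatter) is taken as small, toward a somewhat lower number, and not clearly beyond the scatter. Compound 4 is therefore estimated at 60000 nM, with a range from 20000 nM to 150000 nM.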

Compound 4, half-maximal cytotoxic concentration: 31000 nM
The estimate for compound 4 lay 1.9-fold (0.29 log units) above the measured number; the measured number falls inside the stated range.
By their numbers in this assay, from the lowest: compounds 2 and 4 (each within the scatter of the next); then compound 3.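

In this assay this position now has its first measured step, an at least 3.2-fold lower number from compound 1 to compound 4 (0.50 log units; beyond the scatter), with (furan-2-yl)methoxy in place of methylsulfanyl. A change at this place on the saturated chain carbon can therefore move the number beyond the scatter, toward higher toxicity in this test. Compound 1 stands only at a limit, so the step gives a floor and not a size: the limit of > 100000 nM in this assay, at which 1 of the 4 values shown sits.

The compounds shown leave open whether the furan ring itself matters or the larger group alone would do the same. They also leave open what an amine or a carboxylic acid would give at this place.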